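Hydroxybenzyl amide expected to fall below compound 2

The source may hold more compounds than are shown below. What is called first, only, known or untested is meant among the compounds shown, and "the series" means these compounds.

Measured in a functional assay on CWR22R cells (Homo sapiens) for inhibition, read by MTT assay; a higher number here means a weaker inhibitor of growth, a lower number a stronger inhibitor of growth:
- compound 1 `CC1=C(/C=C/C(C)=C/C=C/C(C)=C\C(=O)Nc2ccc(O)cc2)C(C)(C)CCC1n1ccnc1`: 3890 nM
- compound 2 `CC1=C(/C=C/C(C)=C/C=C/C(C)=C\C(=O)Nc2ccc(F)cc2)C(C)(C)CCC1n1ccnc1`: 8120 nM

Of the two measured compounds, compound 2 has the higher number in this assay, so it is the weaker inhibitor of growth. Its nearest and only neighbour is compound 1, which shares the core. The next compound, compound 3 `CC1=C(/C=C/C(C)=C/C=C/C(C)=C\C(=O)NCc2ccc(O)cc2)C(C)(C)CCC1n1ccnc1`, has not yet been measured. It differs from compound 2 as follows: 4-hydroxybenzyl in place of 4-fluorophenyl on an amide-type nitrogen. Thus 4-hydroxybenzyl replaces 4-fluorophenyl on an amide-type nitrogen.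

For the measured compounds named here, only one measured step bears on this change, and only on part of it. Fluoro in place of hydroxy on an aromatic carbon gave a 2.1-fold higher number from compound 1 to compound 2 (0.32 log units; beyond the scatter), a modest step. Compound 3 regains a hydroxy group, so that step, read backwards, points towards a lower number of similar size. Going by the values given here, no measured compound tests the benzyl form, so the uncertainty is wide. The expected change is a 2.1-fold lower number from compound 2 to compound 3 (0.32 log units; beyond the scatter). For compound 3 the estimated value is 3900 nM, with an expected range of 1500 nM to 10000 nM.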

Compound 3, concentration for 50% growth inhibition: 1860 nM
Compound 3: the middle estimate sits 2.1-fold (0.32 log units) above what was measured; low and high end bracket the measured number.
By their numbers in this assay, from the lowest: compound 3; then compound 1; then compound 2.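

In this assay, for the compounds shown here, the single change of 4-hydroxybenzyl in place of 4-hydroxyphenyl on the amide-type nitrogen gave a 2.1-fold lower number from compound 1 to compound 3 (0.32 log units; beyond the scatter) and so shows that this position responds to the form of the group itself, with the hydroxy group held constant, whereas compounds 1 and 2 differed only in the substituent on the aromatic ring. The wider exchange of 4-fluorophenyl for 4-hydroxybenzyl gave a 4.4-fold lower number from compound 2 to compound 3 (0.64 log units; beyond the scatter) and makes compound 3 the strongest inhibitor of growth among these three, with both of its steps beyond the usual scatter. Nothing available explains either step or says why the benzyl form goes with the lower number.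

It remains open whether the benzyl form would give a similar step with fluoro on the ring, since only its hydroxy form is shown here. Also open, on these data alone, is whether a longer chain carrying the ring on the amide-type nitrogen, or an amine or a carboxylic acid in place of the hydroxy group, would lower the number further or raise it.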